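This account rests on a few compounds, and the source may have more. Where it says the series, first, only, none or still open, it means among the compounds named here.

Compound 3 `CCc1ccc(-c2cn3ccnc3c(-c3ccc4ncn(Cc5ccccc5)c4c3)n2)cc1` gives 25% in a functional assay on IGROV-1 cells (Homo sapiens) for inhibition, read by sulforhodamine B assay, with a stated time of 48 h, tested at 10 uM; a higher number here means more inhibition at the concentration tested (going by the name of the read-out), a lower number less inhibition. Among the three compounds measured it stands second highest: compound 2 `O=Cc1ccc(-c2cn3ccnc3c(-c3ccc4ncn(C5CCCCC5)c4c3)n2)cc1` gives 21.3%, within the usual scatter of compound 3, while compound 1 `COc1ccc(-c2cn3ccnc3c(-c3ccc4ncn(C5CCCCC5)c4c3)n2)cc1` gives 53.4%, a gap beyond the scatter. Compound 4 `Cc1cccc(-c2cn3ccnc3c(-c3ccc4ncn(Cc5ccccc5)c4c3)n2)c1` differs from compound 3 by 3-methylphenyl in place of 4-ethylphenyl on an aromatic carbon. Among the measured compounds shown here, the only measured step, a number 32.1 percentage points lower from compound 1 to compound 2 (beyond the scatter), also alters the phenyl group, but it trades a methoxy for a formyl rather than one alkyl for another, so it bears only loosely on the present change. For the measured compounds named here, with no closer precedent, compound 4 is expected to show no step beyond the scatter, no change at the digits printed from compound 3 to compound 4 (within the scatter). Compound 4 is therefore estimated at 25%, between 5% and 50%.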

Compound 4, a percentage reported as inhibition, at one concentration (the size of the read-out at that concentration, not a potency): 9.51%
For compound 4 the middle estimate is 15.5 percentage points above the measured one; the measured number falls inside the stated range.
By their numbers in this assay, from the lowest: compound 4; then compounds 2 and 3 (each within the scatter of the next); then compound 1.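

In this assay, the step of a number 15.5 percentage points lower from compound 3 to compound 4 (beyond the scatter) shows that this position responds even when one plain hydrocarbon-substituted phenyl replaces another. Neither 4-ethylphenyl nor 3-methylphenyl has a hydrogen-bond donor or acceptor, so the earlier methoxy-to-formyl step did not cover this kind of swap. Nothing available explains the lower inhibition.

Because the chain and its ring position change together, the step cannot say which matters; 4-methylphenyl would help separate them. On these data alone, the effect of an amine at this position also remains open.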